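The source may report more compounds than this note shows. Statements on the series, on what has been measured and on what is new or still open speak of the compounds shown alone.

Measured in a functional assay on HT-29 cells (Homo sapiens) for inhibition, read by luminescence and CellTiter-Glo, with a stated time of 24 h; a higher number here means that more compound is needed for the effect, a lower number that less compound is needed:

- compound 1 `CN1C(=S)[C@@H](NC(=O)c2nc(Cc3ccccc3)n(C)n2)COc2ccccc21`: 2.5 nM
- compound 2 `CC(C)n1nc(C(=O)N[C@H]2COc3ccccc3N(C)C2=S)nc1Cc1ccccc1`: 360 nM
- compound 3 `CN1C(=S)[C@@H](NC(=O)c2nc(Cc3ccccc3)n(CC3COC3)n2)COc2ccccc21`: 2830 nM

Compound 3 has the highest number of the three, and all three differ only in the group on the aromatic nitrogen. Compound 4 `CN1C(=S)[C@@H](NC(=O)c2nc(Cc3ccccc3)n(C3CCN(C(=O)OC(C)(C)C)C3)n2)COc2ccccc21` changes that same place: a group of 12 heavy atoms (9 carbon, 1 nitrogen, 2 oxygen; one five-membered non-aromatic ring with 1 hetero atom) in place of a group of 5 heavy atoms (4 carbon, 1 oxygen; one four-membered non-aromatic ring with 1 hetero atom), on an aromatic nitrogen. The new group sits on an aromatic nitrogen of a five-membered aromatic ring, next to the ring atom that bears a benzyl group.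

For the measured compounds named here, three measured steps bear on this. The large ones are a 140-fold higher number from compound 1 to compound 2 (2.16 log units; beyond the scatter) and a 1100-fold higher number from compound 1 to compound 3 (3.05 log units; beyond the scatter), and the modest one is a 7.9-fold higher number from compound 2 to compound 3 (0.90 log units; beyond the scatter). Across compound 1, compound 2 and compound 3 the number rises as the group grows, and none of the three goes against this. Going by the values given here, three compounds make a thin basis, however, and none carries a group as large as the one in compound 4. The trend suggests no drop from compound 3, so in this assay no step beyond the scatter is the central expectation, with the risk lying towards higher numbers. The expected step is a 1.4-fold higher number from compound 3 to compound 4 (0.15 log units; within the scatter). For compound 4 the estimate is 4000 nM, with an expected range of 700 nM to 20000 nM.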

Compound 4, half-maximal effective concentration: > 10000 nM
Compound 4 ended at the assay's limit; the forecaster's own chance of this, stated with the estimate: 20%; at least 2.5-fold (0.39 log units) between middle value and limit.
By their numbers in this assay, from the lowest: compound 1; then compound 2; then compound 3. At a limit, above all of these: compound 4.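

In this assay compound 4 stands at a limit and not at a number: the limit of > 10000 nM in this assay, at which 1 of the 4 values shown sits. The steps are therefore floors: an at least 3.5-fold higher number from compound 3 to compound 4 (0.54 log units; beyond the scatter), an at least 27-fold higher number from compound 2 to compound 4 (1.44 log units; beyond the scatter) and an at least 4000-fold higher number from compound 1 to compound 4 (3.60 log units; beyond the scatter). For the compounds shown here, the earlier compounds reached only (oxetan-3-yl)methyl; this result shows that the number on this aromatic nitrogen does not fall back with a still larger group, here one of 12 heavy atoms with a five-membered non-aromatic ring, and none of compound 1, compound 2, compound 3 or compound 4 goes against the rise with group size, though the true size of the last step stays unknown.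

Group size cannot yet be separated from group type, as compound 4 differs from compound 3 in ring, size and double bond together, so the same five-membered ring carrying a free amine would show whether the ring alone keeps the number this high. An ethyl group would show how the large rise from methyl to isopropyl builds up, and a carboxylic acid on a short chain would test a different kind of group at this place.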